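The compounds below may be only part of what the source reports. "The series", "measured", "known", "first", "only" and "open" are said of these compounds alone.

Compound 3 `CC1CCN(c2nc(Cl)nc3c2ncn3Cc2ccc(/C=C/C(=O)Nc3ccccc3N)cc2)CC1` sits second highest of the three numbers in a functional assay on HCT-116 cells (Homo sapiens) for antiproliferative activity, read by CCK-8 assay, with a stated time of 72 h, tested at 8 uM; on this read-out higher numbers stand for a stronger effect at the one concentration tested and lower numbers for a weaker effect: compound 3 gives 26.9%, compound 2 `Cc1ccc(Nc2nc(Cl)nc3c2ncn3Cc2ccc(/C=C/C(=O)Nc3ccccc3N)cc2)cc1` gives 15%, and compound 1 `Nc1ccccc1NC(=O)c1ccc(Cn2cnc3c(Nc4cccc(OC(F)(F)F)c4)nc(Cl)nc32)cc1` gives 46.6%. For the measured compounds named here, the one measured step is a number 11.9 percentage points higher from compound 2 to compound 3 (beyond the scatter). Compound 4 `Nc1ccccc1NC(=O)/C=C/c1ccc(Cn2cnc3c(Nc4cccc(OC(F)(F)F)c4)nc(Cl)nc32)cc1` differs from compound 3 in one place, ((3-(trifluoromethoxy)phenyl)amino in place of 4-methylpiperidin-1-yl on an aromatic carbon), on an aromatic carbon of a six-membered aromatic ring with 2 nitrogen, next to the ring nitrogen and meta to a chloro group. The step from compound 2 to compound 3 bears on this change in the opposite sense, an amino-linked aromatic ring giving way to the saturated ring, and it was modest; compound 4 now puts an amino-linked aromatic ring back, so a modest step downward would follow from that alone. Against this, compound 1 carries the same (3-(trifluoromethoxy)phenyl)amino group with a different linker and gives the highest number of the set, so the direction is uncertain. The expected step is a number 3.1 percentage points higher from compound 3 to compound 4 (within the scatter), roughly within the scatter. Compound 4 is estimated at 30%, with a range from 14% to 50%.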

Compound 4, a percentage reported as inhibition, at one concentration (the size of the read-out at that concentration, not a potency): 5.23%
Estimate against measurement, compound 4: 24.8 percentage points above; the whole stated range lies above it.
By their numbers in this assay, from the lowest: compounds 4 and 2 (each within the scatter of the next); then compound 3; then compound 1.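

In this assay, the (3-(trifluoromethoxy)phenyl)amino group on this aromatic carbon gives a number 21.7 percentage points lower from compound 3 to compound 4 (beyond the scatter) in the series with the ethenyl linker, while the change of aryl group on the nitrogen gives a number 9.8 percentage points lower from compound 2 to compound 4 (within the scatter) and stays within the scatter. The 4-methylpiperidin-1-yl group therefore stands above both amino-linked aromatic rings in this series. With the (3-(trifluoromethoxy)phenyl)amino group held constant, the linker change gives a number 41.4 percentage points lower from compound 1 to compound 4 (beyond the scatter) and is the large step in the set, and no measurement shown accounts for these differences. Open, from the compounds shown here alone, is whether the saturated ring keeps its edge when the (2-aminophenyl)carbamoyl group sits directly on the aromatic ring, as in compound 1. Also open, going by these compounds, is how a morpholine or a simple alkylamine would compare with 4-methylpiperidin-1-yl on this carbon.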